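This account rests on a few compounds, and the source may have more. Where it says the series, first, only, none or still open, it means among the compounds named here.

Compound 1 `CC[C@@H]1C(=O)N(C)c2cnc(Nc3ccc(S(=O)(=O)NC)cc3)nc2N1C1CCCC1`: 3.4 nM in an assay for inhibition of serine/threonine-protein kinase PLK2 (Homo sapiens), read by FRET and Z'-LYTE, with a stated time of 1 h; on this read-out lower numbers stand for stronger inhibition and higher numbers for weaker inhibition
Compound 2 `CCCNC(=O)c1ccc2c(ccn2-c2ncc3c(n2)N(C2CCCC2)[C@H](CC)C(=O)N3C)c1`: 11.4 nM in this assay

Among the measured compounds shown here, of the two compounds measured in this assay, compound 1 has the lower number; compound 2 stands beyond the scatter above it, and the two share a core but differ at more than one place, so no single step between them can be read. Compound 3 `CC[C@@H]1C(=O)N(C)c2cnc(Nc3ccc(S(=O)(=O)NCC(C)C)cc3)nc2N1C1CCCC1` has not yet been measured. It differs from compound 1 in one place: isopropyl in place of hydrogen on a saturated chain carbon bound to a sulfonamide nitrogen. For the measured compounds named here, no measured pair shows this change, so the expectation rests only on where compound 1 stands, with its value of 3.4 nM in this assay. The step from compound 1 to compound 3 is expected to be small, a 1.5-fold higher number from compound 1 to compound 3 (0.17 log units; within the scatter), not clearly beyond the scatter in either direction. Compound 3 is accordingly expected to give about 5 nM in this assay, within a range from 1.5 nM to 16 nM.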

Compound 3, half-maximal inhibitory concentration: 21.8 nM
Compound 3: the middle estimate sits 4.4-fold (0.64 log units) below what was measured; measured number above the stated range.
By their numbers in this assay, from the lowest: compound 1; then compounds 2 and 3 (each within the scatter of the next).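

In this assay, among the compounds shown here, the change from methylsulfamoyl to isobutylsulfamoyl gives a 6.4-fold higher number from compound 1 to compound 3 (0.81 log units; beyond the scatter) and provides the first reading at this position. It shows that the group on the sulfonamide nitrogen of compound 1 is not free to vary without consequence: adding 3 heavy atoms, all carbon, with no ring, no hydrogen-bond donors or acceptors and no net charge, is enough to give a clear loss of inhibition. No available evidence bears on why this isopropyl addition weakens inhibition.

With one step at this position, the compounds shown leave open whether chain length or branching accounts for the loss. An ethyl group, an unbranched propyl chain or a chain ending in an amine or a carboxylic acid could help separate these possibilities.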